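The compounds below may be only part of what the source reports. "The series", "measured", "known", "first", "only" and "open" are said of these compounds alone.

Two compounds have so far been measured in a functional assay on the whole organism with Scenedesmus acutus as the target, read by spectrophotometry (on this read-out lower numbers stand for stronger inhibition and higher numbers for weaker inhibition), with these results:

compound 1 `O=c1c2c(sn1-c1ccc(C(F)(F)F)cc1)CCCC2` gives 55000 nM
compound 2 `O=C1C2=C(CCCC2)S(=O)(=O)N1c1ccc(Cl)cc1` gives 5250 nM

Compound 2 holds the lower number of the two, which means the stronger inhibition. Its value of 5250 nM stands against compound 1 at 55000 nM and this gap lies beyond the usual scatter.

Compound 3 `CC(C)OC(=O)c1cc(N2C(=O)C3=C(CCCC3)S2(=O)=O)ccc1Cl` has not yet been measured. It differs from compound 2 in one place isopropoxycarbonyl in place of hydrogen on an aromatic carbon with isopropoxycarbonyl in place of hydrogen on an aromatic carbon, ortho to a chloro group and meta to a large group.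

Among the measured compounds shown here, no measured pair shows the effect of this change, so any expectation here is a judgement with wide uncertainty. A moderate move to a lower number, beyond the scatter, is expected in this assay for this change. The estimated step is a 5.8-fold lower number from compound 2 to compound 3 (0.77 log units; beyond the scatter) in this assay and a step within the scatter cannot be ruled out. For compound 3 the expected value is 900 nM with an estimated range from 120 nM to 6500 nM in this assay once it is measured.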

Compound 3, half-maximal inhibitory concentration: 501 nM
Compound 3: the middle estimate sits 1.8-fold (0.25 log units) above what was measured, within the range that was stated.
By their numbers in this assay, from the lowest: compound 3; then compound 2; then compound 1.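

In this assay, among the compounds shown here, putting isopropoxycarbonyl in place of hydrogen on the aromatic carbon ortho to a chloro group and meta to a large group gives a 10-fold lower number from compound 2 to compound 3 (1.02 log units; beyond the scatter), and this is the first single-place change whose effect can be read, since compound 1 and compound 2 differ in more than one place. It shows that this position accepts a group of 6 heavy atoms, with no loss of inhibition and a clear gain in it, while the chloro group stays in place. No measurement shown here bears on what lies behind this gain, so the step stands as an observation about this one pair.

The compounds shown leave open whether the gain belongs to the isopropoxycarbonyl group itself or would also come with a carboxylic acid, a methoxycarbonyl group, a longer ester chain or an amine on the same carbon. They also leave open whether the same step would appear without the chloro group, as this single pair tests the change in only one setting.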